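The source may hold more compounds than are shown below. What is called first, only, known or untested is meant among the compounds shown, and "the series" means these compounds.

Compound 1, `C#Cc1cccc(Nc2ncnc3ccc(NC(=O)Nc4ccc(CN5CCN(C)CC5)cc4)cc23)c1`: in a functional assay on A549 cells (Homo sapiens) for antiproliferative activity, read by MTT assay, with a stated time of 72 h (on this read-out lower numbers stand for stronger inhibition and higher numbers for weaker inhibition), compound 1 gives 5170 nM.
Compound 2, `O=C(Nc1ccc(CN2CCCC2)cc1)Nc1ccc2ncnc(Nc3cccc(C(F)(F)F)c3)c2c1`: in this assay compound 2 gives 830 nM.
Compound 3, `C[C@@H](Nc1ncnc2ccc(NC(=O)Nc3ccc(CN4CCN(C)CC4)cc3)cc12)c1ccccc1`: in this assay compound 3 gives > 10000 nM, which is a limit of the assay and not a number.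

Among the numbers shown, compound 2 stands lowest; its nearest neighbour is compound 1, whose number is higher by a margin beyond the scatter. Compound 1 and compound 2 differ in more than one place, so their values are compared only as they stand. Compound 4, `O=C(Nc1ccccc1)Nc1ccc2ncnc(Nc3cccc(C(F)(F)F)c3)c2c1`, is yet to be measured. It differs from compound 2 by hydrogen in place of (pyrrolidin-1-yl)methyl on an aromatic carbon. For the measured compounds named here, the one measured step, an at least 1.9-fold higher number from compound 1 to compound 3 (0.28 log units; that floor lies within the scatter), alters the group on the nitrogen attached to the shared core and not the urea tail, so it does not bear on this change. Going by the values given here, with no measured step bearing on it, the direction is uncertain; a loss of the pyrrolidinylmethyl group is expected to give a moderately higher number, a 2.4-fold higher number from compound 2 to compound 4 (0.38 log units; beyond the scatter). Compound 4 is therefore estimated at 2000 nM, within a range from 500 nM to 8000 nM.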

Compound 4, half-maximal inhibitory concentration: > 10000 nM
Compound 4 was reported as a limit; the forecaster's own chance of this, stated with the estimate: 10%; at least 5.0-fold (0.69 log units) between middle value and limit.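

In this assay, taking away the (pyrrolidin-1-yl)methyl group, para to a large group on the six-membered aromatic ring of the urea tail, gives an at least 12-fold higher number from compound 2 to compound 4 (1.08 log units; beyond the scatter). For the compounds shown here, the earlier step altered only the group on the nitrogen attached to the shared core, so this is the first measured change at this position, and it shows that the number of compound 2 does not survive the bare phenyl. Compound 4 gives > 10000 nM, which is a limit of the assay and not a number, so the step gives only a floor for the size of this change: the limit of > 10000 nM in this assay, at which 2 of the 4 values shown sit.

On these data alone, whether a morpholinylmethyl, a dimethylaminomethyl or a plain methyl group at this place would keep the number of compound 2 remains open. Also open, as far as these compounds go, is whether the same loss would hold with the 3-ethynylphenyl group of compound 1 on the core nitrogen.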